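The source may hold more compounds than are shown below. What is called first, only, known or untested is meant among the compounds shown, and "the series" means these compounds.

Measured compounds in a functional assay on ACHN cells (Homo sapiens) for cytotoxicity, read by sulforhodamine B assay, tested at 10 uM; on this read-out higher numbers stand for more inhibition at the one concentration tested (going by the name of the read-out) and lower numbers for less inhibition:
Compound 1 `CC(=O)OC[C@H]1O[C@@H](n2cc(-c3cc(-c4ccc(C(C)(C)C)cc4)no3)c(=O)[nH]c2=O)C[C@@H]1OC(C)=O` — compound 1 gives 74.7%
Compound 2 `CC(=O)OC[C@H]1O[C@@H](n2cc(-c3cc(-c4ccccc4)no3)c(=O)[nH]c2=O)C[C@@H]1OC(C)=O` — compound 2 gives 97.6%
Compound 3 `CCc1ccc(-c2cc(-c3cn([C@H]4C[C@H](OC(C)=O)[C@@H](COC(C)=O)O4)c(=O)[nH]c3=O)on2)cc1` — compound 3 gives 92%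

Compound 3 stands second highest of the three numbers. Its nearest neighbour is compound 2: a number 5.6 percentage points lower from compound 2 to compound 3 (within the scatter), so the two cannot be told apart. Its furthest is compound 1: a number 17.3 percentage points higher from compound 1 to compound 3 (beyond the scatter). The other step in the series is a number 22.9 percentage points higher from compound 1 to compound 2 (beyond the scatter).

Compound 4 `CC(=O)OC[C@H]1O[C@@H](n2cc(-c3cc(C)no3)c(=O)[nH]c2=O)C[C@@H]1OC(C)=O` has not been measured in this assay. Its change from compound 3 is methyl in place of 4-ethylphenyl on an aromatic carbon. The measured steps all concern what sits on the aromatic carbon of the phenyl ring, exchanging tert-butyl for hydrogen or ethyl; none removes the phenyl ring itself. They therefore bear on the step to compound 4 only loosely: they show that exchanges at that end of the molecule moved the read-out by modest amounts or not beyond the scatter. Loss of the whole 4-ethylphenyl is a larger change than any measured, and the direction is not given by the data. The expectation is a modest fall, a number 22 percentage points lower from compound 3 to compound 4 (beyond the scatter), with wide uncertainty. Compound 4 is estimated at 70%, within 35% to 98%.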

Compound 4, a percentage reported as inhibition, at one concentration (the size of the read-out at that concentration, not a potency): 96.4%
Estimate against measurement, compound 4: 26.4 percentage points below; measured number inside the range.
By their numbers in this assay, from the lowest: compound 1; then compounds 3, 4 and 2 (each within the scatter of the next).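

In this assay the aromatic ring on this carbon of the five-membered ring turns out not to be required for the read-out at the one concentration tested: a number 4.4 percentage points higher from compound 3 to compound 4 (within the scatter) and a number 1.2 percentage points lower from compound 2 to compound 4 (within the scatter), so methyl, with no ring and far fewer heavy atoms, cannot be told apart from 4-ethylphenyl or phenyl. Going by these compounds alone, the one step beyond the scatter involving compound 4 is a number 21.7 percentage points higher from compound 1 to compound 4 (beyond the scatter), which leaves 4-(tert-butyl)phenyl as the only group at this position among the four compounds tied to a lower number, whereas the earlier compounds could only show differences among groups that all kept the phenyl ring. No measured property is available that bears on this result.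

Open, going by these compounds, is whether an amine or a carboxylic acid on this carbon would match methyl, and whether a longer chain such as n-butyl would keep the number or lower it as in compound 1. A read-out at one concentration also leaves open whether compound 2, compound 3 and compound 4 would show a stronger or weaker effect than one another at other concentrations.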